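The source may report more compounds than this note shows. Statements on the series, on what has been measured and on what is new or still open speak of the compounds shown alone.

Compound 3, with the structure `CCO/C(O)=C1\C(COCCn2cnc3ccccc32)=NC(C)=C(C(=O)OC)C1c1ccccc1Cl`, gives 20 nM in a functional assay (aorta) with Rattus norvegicus as the target (on this read-out lower numbers stand for stronger inhibition and higher numbers for weaker inhibition), the lowest of the three numbers measured here. Compound 2, `CCO/C(O)=C1\C(COCCn2cc(N)n(C)c2=O)=NC(C)=C(C(=O)OC)C1c1ccccc1Cl`, gives 25.1 nM, and the gap a 1.3-fold lower number from compound 2 to compound 3 (0.10 log units; within the scatter) means the two cannot be told apart. Compound 1, `CCOC(=O)c1cnnn1CCOCC1=NC(C)=C(C(=O)OC)C(c2ccccc2Cl)/C1=C(\O)OCC`, gives 100 nM, and the step of a 5.0-fold lower number from compound 1 to compound 3 (0.70 log units; beyond the scatter) is the largest difference seen.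

Compound 4, `CCO/C(O)=C1\C(COCCn2ccnn2)=NC(C)=C(C(=O)OC)C1c1ccccc1Cl`, differs from compound 3 in one place: 1H-1,2,3-triazol-1-yl in place of 1H-benzimidazol-1-yl on a saturated chain carbon, two bonds along the chain from an oxygen on a saturated carbon. Among the compounds with values here, the step that bears most on this is the one from compound 1 to compound 3, where a 5-(ethoxycarbonyl)-1H-1,2,3-triazol-1-yl group was replaced by 1H-benzimidazol-1-yl, giving a 5.0-fold lower number from compound 1 to compound 3 (0.70 log units; beyond the scatter). Within the data shown here, compound 4 carries a plain 1H-1,2,3-triazol-1-yl group, so it sits between those two cases in its substituent, and no measured pair shows what the ethoxycarbonyl part alone contributes. A step of a 2.0-fold higher number from compound 3 to compound 4 (0.30 log units; within the scatter) is therefore expected, toward a higher number but with wide uncertainty. For compound 4 the estimate in this assay is 40 nM, with a likely range from 15 nM to 120 nM.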

Compound 4, half-maximal inhibitory concentration: 15.9 nM
Estimate against measurement, compound 4: 2.5-fold (0.40 log units) above; measured number inside the range.
By their numbers in this assay, from the lowest: compounds 4, 3 and 2 (each within the scatter of the next); then compound 1.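

Within the data shown here, the step of a 6.3-fold lower number from compound 1 to compound 4 (0.80 log units; beyond the scatter), with hydrogen in place of ethoxycarbonyl on an aromatic carbon, isolates a change that the earlier compounds left mixed with a change of ring: the higher number of compound 1 goes with the ethoxycarbonyl group on the 1H-1,2,3-triazol-1-yl ring. The steps of a 1.3-fold lower number from compound 3 to compound 4 (0.10 log units; within the scatter) and a 1.6-fold lower number from compound 2 to compound 4 (0.20 log units; within the scatter) both lie within the scatter, so compound 2, compound 3 and compound 4 cannot be told apart, even though the groups on this saturated chain carbon differ in size and ring type. Nothing measured here explains these numbers.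

On these data alone, whether a methyl or a carboxylic acid on that aromatic carbon would behave like ethoxycarbonyl or like hydrogen remains open. So does the outcome of an open-chain amine in place of the ring, or of a longer chain carrying the 1H-1,2,3-triazol-1-yl group.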